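Swapping the alkynol for a fluoropyridine: expected microsomal clearance

The compounds below may be only part of what the source reports. "The series", "measured", "known", "first", "only" and "open" are said of these compounds alone.

Compound 1 `CC(C)(O)C#Cc1cc(C(O)(C(F)(F)F)C(F)(F)F)cnc1N1CCN(S(=O)(=O)c2ccc(N)nc2)CC1` — 16 mL.min-1.g-1
Compound 2 `Nc1ccc(S(=O)(=O)N2CCN(c3ncc(C(O)(C(F)(F)F)C(F)(F)F)cc3-c3ccoc3)CC2)cn1` — 57 mL.min-1.g-1
Compound 3 `Nc1ccc(S(=O)(=O)N2CCN(c3ncc(C(O)(C(F)(F)F)C(F)(F)F)cc3-c3ccncc3)CC2)cn1` — 31 mL.min-1.g-1

Three compounds sharing one core have been run in an ADME assay (liver) for metabolic stability, with Liver microsome (Rattus norvegicus) as the target, using microsomes and NADPH, with a stated time of 30 min, tested at 1 uM; on this read-out lower numbers stand for slow clearance and higher numbers for fast clearance. Compound 1 gives 16 mL.min-1.g-1, the lowest of the three numbers. Its nearest neighbour is compound 3 at 31 mL.min-1.g-1, reached by a 1.9-fold higher number from compound 1 to compound 3 (0.29 log units; within the scatter), a step within the scatter. Its furthest neighbour is compound 2 at 57 mL.min-1.g-1, reached by a 3.6-fold higher number from compound 1 to compound 2 (0.55 log units; beyond the scatter), a step beyond the scatter.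

Compound 4 `Nc1ccc(S(=O)(=O)N2CCN(c3ncc(C(O)(C(F)(F)F)C(F)(F)F)cc3-c3cnccc3F)CC2)cn1` has not yet been measured in this assay. It differs from compound 1 in one place: 4-fluoropyridin-3-yl in place of 3-hydroxy-3-methylbut-1-yn-1-yl on an aromatic carbon. The two measured steps that bear on this change both replace the same 3-hydroxy-3-methylbut-1-yn-1-yl group at the same aromatic carbon with a ring, and both move the number upward, one of them by a 3.6-fold higher number from compound 1 to compound 2 (0.55 log units; beyond the scatter) and the other by a 1.9-fold higher number from compound 1 to compound 3 (0.29 log units; within the scatter). The entering 4-fluoropyridin-3-yl group is a six-membered aromatic ring with one hetero atom, closer in kind to the pyridin-4-yl of compound 3 than to the furan-3-yl of compound 2, so the expected step is upward but modest. Compound 4 is therefore expected to give 30 mL.min-1.g-1 in this assay, in a range from 15 mL.min-1.g-1 to 60 mL.min-1.g-1, which is the step of a 1.9-fold higher number from compound 1 to compound 4 (0.27 log units; within the scatter).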

Compound 4, intrinsic clearance in microsomes: 22 mL.min-1.g-1
Compound 4: middle estimate off by 1.4-fold (0.13 log units), on the high side; measured number inside the range.
By their numbers in this assay, from the lowest: compounds 1, 4, 3 and 2 (each within the scatter of the next, the first and the last beyond it).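

In this assay the 4-fluoropyridin-3-yl group on this aromatic carbon stays close to the 3-hydroxy-3-methylbut-1-yn-1-yl group it replaces, with a 1.4-fold higher number from compound 1 to compound 4 (0.14 log units; within the scatter), so compound 3 is no longer the only six-membered aromatic ring at this position that cannot be told apart from compound 1. The two pyridine-bearing compounds also cannot be told apart from each other, with a 1.4-fold lower number from compound 3 to compound 4 (0.15 log units; within the scatter), although that change moves the ring nitrogen relative to the point of attachment and adds a fluorine at the same time. The furan-3-yl of compound 2 now stands apart from a ring-bearing compound as well as from the alkynol, with a 2.6-fold lower number from compound 2 to compound 4 (0.41 log units; beyond the scatter), a separation that the pair of compound 2 and compound 3 did not show.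

The compounds shown leave open what the fluorine contributes on its own, which a plain pyridin-3-yl group at this carbon would address, and where a phenyl group or a saturated ring such as morpholine would fall relative to these four. No measurement at hand explains why the numbers fall as they do.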